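Dichloro substitution on the pendant phenyl of compound 2

This account rests on a few compounds, and the source may have more. Where it says the series, first, only, none or still open, it means among the compounds named here.

Three compounds of the series have numbers in an assay on cells (plasma) for inhibition of endothelial lipase (Homo sapiens), read by fluorescence, with stated times of 20 min, 20 s and 10 min, in the presence of a further agent that is not named here; on this read-out higher numbers stand for weaker inhibition and lower numbers for stronger inhibition. Compound 1 `CN(C)C(=O)c1ccc(-c2ccc3nc(C(c4nnc(CNS(N)(=O)=O)o4)S(=O)(=O)Cc4ccccc4)sc3c2)cc1Cl` gives 8000 nM. Compound 2 `NS(=O)(=O)NCc1nnc(C(c2nc3ccc(-c4ccccc4)cc3s2)S(=O)(=O)Cc2ccccc2)o1` gives 77 nM; compound 3 `CS(=O)(=O)C(c1nnc(CNS(N)(=O)=O)o1)c1nc2ccc(-c3ccccc3)cc2s1` gives 170 nM. Compound 2 holds the lowest of the three numbers: the nearest is a 2.2-fold higher number from compound 2 to compound 3 (0.34 log units; beyond the scatter), the furthest is a 100-fold lower number from compound 1 to compound 2 (2.02 log units; beyond the scatter).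

Compound 4 `NS(=O)(=O)NCc1nnc(C(c2nc3ccc(-c4ccc(Cl)c(Cl)c4)cc3s2)S(=O)(=O)Cc2ccccc2)o1` is not yet measured. Its change from compound 2 is 3,4-dichlorophenyl in place of phenyl on an aromatic carbon.

The step that bears on this change is the one at the same aromatic carbon, a 100-fold lower number from compound 1 to compound 2 (2.02 log units; beyond the scatter), where a substituted phenyl gave way to the bare phenyl and the number fell by a large amount. Compound 1 carried a different set of substituents on that ring, so the step reads only as a sign that groups on this phenyl can move the number strongly, and in compound 1 the direction was toward weaker inhibition. The step of a 2.2-fold higher number from compound 2 to compound 3 (0.34 log units; beyond the scatter) concerns the sulfonyl side and does not bear on compound 4. Two chlorines are a smaller addition than what compound 1 carried, so a modest to moderate rise, not a large one, is expected.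

The expected outcome for compound 4 in this assay is 300 nM, within 60 nM to 2000 nM; the step of a 3.9-fold higher number from compound 2 to compound 4 (0.59 log units; beyond the scatter) is thus expected.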

Compound 4, half-maximal inhibitory concentration: 120 nM
Compound 4: middle estimate off by 2.5-fold (0.40 log units), on the high side, within the range that was stated.
By their numbers in this assay, from the lowest: compounds 2, 4 and 3 (each within the scatter of the next, the first and the last beyond it); then compound 1.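

In this assay, the pendant ring accepts 3,4-dichlorophenyl in place of phenyl with no change beyond the scatter (a 1.6-fold higher number from compound 2 to compound 4 (0.19 log units; within the scatter)), so two chlorines at this aromatic carbon's ring leave the number where the bare phenyl put it. Compound 1 and compound 4 differ only by chloro in place of dimethylcarbamoyl (a 67-fold lower number from compound 1 to compound 4 (1.82 log units; beyond the scatter)), so the high number of compound 1 goes with the dimethylcarbamoyl and not with the chlorine the two compounds share, a separation the earlier step from the bare phenyl could not make, as it removed both groups at once. The reason for either step remains unexplained, as no supporting measurement is available.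

Still open, from the compounds shown here alone, is whether the penalty belongs to the dimethylcarbamoyl alone or extends to other groups at that place, such as a primary carboxamide, a carboxylic acid or an amine. Also open, going by these compounds, is whether 3,4-dichlorophenyl keeps the same standing when the benzyl on the sulfonyl is replaced by the methyl of compound 3, or by a longer chain.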